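The source may hold more compounds than are shown below. What is called first, only, known or untested is meant among the compounds shown, and "the series" means these compounds.

Four compounds share one core, in which a carbonyl carbon carries a double-bonded chain carbon and an aromatic ring. Compound 1 `COc1ccc(-c2cc(/C=C/C(=O)c3ccc(N)cc3)[nH]n2)cc1` gives 3420 nM in a functional assay on KM12 cells (Homo sapiens) for inhibition, read by sulforhodamine B assay, with a stated time of 48 h; on this read-out higher numbers stand for weaker inhibition of growth and lower numbers for stronger inhibition of growth. Compound 3 `COc1ccc(C(=O)/C=C/c2cc(-c3cc(OC)c(OC)c(OC)c3)n[nH]2)cc1OC` gives 2410 nM in this assay. Compound 2 `COc1cc(-c2cc(/C=C/C(=O)c3ccc(Cl)c(Cl)c3)[nH]n2)cc(OC)c1OC` returns only a limit of the assay in this assay, > 100000 nM; so compound 2 stands at the weak end of the numbers shown, and its distance from the others can only be given as a lower bound. Among the measured compounds shown here, the one measured step that starts from compound 2 is an at least 41-fold lower number from compound 2 to compound 3 (1.61 log units; beyond the scatter), and it rests on (the limit of > 100000 nM in this assay, at which 1 of the 3 values shown sits).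

Compound 4 `COc1cc(-c2cc(/C=C/C(=O)c3ccc(F)c(F)c3)[nH]n2)cc(OC)c1OC` differs from compound 2 in one place: 3,4-difluorophenyl in place of 3,4-dichlorophenyl on a carbonyl carbon. For the measured compounds named here, no measured step here exchanges one halogen-bearing ring for another, so the step from compound 2 to compound 3 shows only that leaving the 3,4-dichlorophenyl can matter greatly; it does not tell what the 3,4-difluorophenyl will do. The expectation for compound 4 is therefore a number near the weak end, 50000 nM, within a range of 8000 nM to 300000 nM, which as an estimated step means an at least 2.0-fold lower number from compound 2 to compound 4 (0.30 log units; that floor lies within the scatter).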

Compound 4, concentration for total growth inhibition: 11400 nM
Compound 4: middle estimate off by 4.4-fold (0.64 log units), on the high side; low and high end bracket the measured number.
By their numbers in this assay, from the lowest: compounds 3 and 1 (each within the scatter of the next); then compound 4. At a limit, above all of these: compound 2.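

In this assay, exchanging only the halogens on the ring at the carbonyl carbon gives an at least 8.7-fold lower number from compound 2 to compound 4 (0.94 log units; beyond the scatter), so a clear change at this position does not need the halogens to be replaced by a different kind of group. Compound 2 stands at a limit, so this size is only a floor: the limit of > 100000 nM in this assay, at which 1 of the 4 values shown sits. The 3,4-difluorophenyl still falls short of the 3,4-dimethoxyphenyl, with a 4.7-fold higher number from compound 3 to compound 4 (0.67 log units; beyond the scatter), so the better of the two halogen rings does not match the ring with two methoxy groups.

From the compounds shown here alone, how a nitrile or a carboxylic acid on this ring would compare remains open. Compound 1 differs from the others in more than one place, so the effect of its amine-bearing ring cannot be separated from its other difference.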